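The source may report more compounds than this note shows. Statements on the series, on what has been measured and on what is new or still open speak of the compounds shown alone.

Compound 2 `Cc1ccc(NC(=O)C(=O)NC(c2nc(C)c(CCO)s2)C2CCCCN2)c(F)c1` carries a 2-fluoro-4-methylphenyl group on an amide-type nitrogen. In an ADME assay on TZM-b1 cells (Homo sapiens) for cytotoxicity, read by XTT assay, with a stated time of 3 days (on this read-out lower numbers stand for higher toxicity in this test and higher numbers for lower toxicity in this test), compound 2 gives only a limit of the assay, > 78800 nM. Compound 3 `Cc1ccc(NC(=O)C(=O)NC(c2nc(C)c(CO)s2)C2CCCCN2)c(F)c1` likewise gives only a limit, > 88000 nM. The step that the two limits leave unreadable from compound 2 to compound 3 therefore cannot be read from these two limits. Compound 1 `Cc1nc(C(NC(=O)C(=O)Nc2ccc(Cl)cc2)C2CCCN2)sc1CO`, which carries a 4-chlorophenyl group and a smaller ring, gives 12400 nM in this assay. Compound 4 `Cc1nc(C(NC(=O)C(=O)Nc2ccc(Cl)c(F)c2)C2CCCCN2)sc1CCO` is not yet measured; it differs from compound 2 by 4-chloro-3-fluorophenyl in place of 2-fluoro-4-methylphenyl on an amide-type nitrogen. Going by the values given here, no measured step matches this change, so the expectation rests on the limit of compound 2 and the number of compound 1. Compound 4 is expected near 40000 nM, with a range from 10000 nM to 150000 nM. That expectation corresponds to a step of an at least 1.9-fold lower number from compound 2 to compound 4 (0.29 log units; that floor lies within the scatter).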

Compound 4, half-maximal cytotoxic concentration: 61000 nM
For compound 4 the middle estimate is 1.5-fold (0.18 log units) below the measured one, and the stated range covers the measured number.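

In this assay, going by these compounds alone, placing 4-chloro-3-fluorophenyl on the amide-type nitrogen gives an at least 1.2-fold lower number from compound 2 to compound 4 (0.11 log units; that floor lies within the scatter), the first step at this position that can be read. Because that step is only a floor within the scatter, it does not show that this change truly lowers the number. Its full size stays unknown because compound 2 gives only a limit of the assay: the limit of > 78800 nM in this assay, at which 1 of the 4 values shown sits.

Still open, from the compounds shown here alone, is how the number responds when the group on this nitrogen carries an amine or a carboxylic acid. Also open, going by these compounds, is whether the chlorine alone would give the same reading.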